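The source may hold more compounds than are shown below. What is called first, only, known or untested is meant among the compounds shown, and "the series" means these compounds.

Measured compounds: compound 1 `CCCC(CCC)C(=O)OCCCCOC(=O)c1ccc(C(=O)Nc2ccc3c(c2)C(C)(C)CCC3(C)C)cc1` with 914000 nM, and compound 2 `CCCC(=O)OCCOC(=O)c1ccc(C(=O)Nc2ccc3c(c2)C(C)(C)CCC3(C)C)cc1` with 6290 nM.

In a functional assay on HL-60 cells (Homo sapiens) for inhibition, read by MTT assay, with a stated time of 48 h (on this read-out higher numbers stand for weaker inhibition and lower numbers for stronger inhibition), compound 2 gives 6290 nM, the lowest of the two numbers, while compound 1 gives 914000 nM. Among the compounds with values here, the single measured step, a 150-fold lower number from compound 1 to compound 2 (2.16 log units; beyond the scatter), is large. Compound 3 `CCCC(CCC)C(=O)OCCCOC(=O)c1ccc(C(=O)Nc2ccc3c(c2)C(C)(C)CCC3(C)C)cc1` differs from compound 2 by (((1-propylbutyl)carbonyl)oxy)methyl in place of (propylcarbonyl)oxy on a saturated chain carbon, two bonds along the chain from an oxygen next to a carbonyl group, returning to the acyl group found in compound 1. The step of a 150-fold lower number from compound 1 to compound 2 (2.16 log units; beyond the scatter) therefore bears on it, and a large move back toward compound 1 is expected, a 48-fold higher number from compound 2 to compound 3 (1.68 log units; beyond the scatter). Compound 3 is estimated at 300000 nM, with a range from 30000 nM to 1200000 nM.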

Compound 3, half-maximal inhibitory concentration: 835000 nM
For compound 3 the middle estimate is 2.8-fold (0.44 log units) below the measured one; the measured number falls inside the stated range.
By their numbers in this assay, from the lowest: compound 2; then compounds 3 and 1 (each within the scatter of the next).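

Shortening the chain while keeping the ((1-propylbutyl)carbonyl)oxy group leaves this assay essentially unchanged, with a 1.1-fold lower number from compound 1 to compound 3 (0.04 log units; within the scatter). The large change returns with a 130-fold higher number from compound 2 to compound 3 (2.12 log units; beyond the scatter), so the low number of compound 2 is lost in compound 3 even though the chain carrying the ester is not that of compound 1. Nothing shown accounts for this difference.

On these data alone, it remains open how the (propylcarbonyl)oxy group behaves on the chain of compound 3, taken apart from the change of acyl group. As far as these compounds go, how an amine or a carboxylic acid would read at this position is also open.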